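Swapping the ring nitrogen substituent in a thiazolidinone series

This account rests on a few compounds, and the source may have more. Where it says the series, first, only, none or still open, it means among the compounds named here.

Measured compounds:
compound 1, `CCOC(=O)c1sc(N2C(=O)CSC2c2cccc(C(=O)NCCCCn3cccn3)c2)nc1C`: 430 nM
compound 2, `O=C(NCCCCc1ccccc1)c1cc(F)cc(C2SCC(=O)N2c2ccccn2)c1`: 14.2 nM

Both compounds were tested in a functional assay on HOS-TE85 cells (Homo sapiens) for inhibition, read by CCK-8 assay, with a stated time of 72 h; on this read-out higher numbers stand for weaker inhibition and lower numbers for stronger inhibition. Compound 1 gives 430 nM, and compound 2 gives 14.2 nM. Of the two numbers, compound 1 has the higher one, and the gap to compound 2 lies beyond the usual scatter, so compound 1 is the weaker inhibitor of the pair in this assay.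

The next compound, compound 3, `O=C(NCCCCn1cccn1)c1cccc(C2SCC(=O)N2c2cc(F)ccn2)c1`, differs from compound 1 in one place only: 4-fluoropyridin-2-yl in place of 5-(ethoxycarbonyl)-4-methyl-1,3-thiazol-2-yl on an amide-type nitrogen in a ring. The group that enters is a small six-membered aromatic ring; the group that leaves is the larger ester-bearing thiazole.

Within the data shown here, no measured pair isolates this particular change, so the size of the step can only be guessed. Compound 2, which also carries a pyridine-type ring on the amide-type nitrogen of the shared core, sits at the stronger end of what has been measured. On that basis, a step toward stronger inhibition is expected, estimated at a 7.2-fold lower number from compound 1 to compound 3 (0.86 log units; beyond the scatter) in this assay. For compound 3 the expected value in this assay is 60 nM, with a plausible range from 15 nM to 250 nM.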

Compound 3, half-maximal inhibitory concentration: 33.2 nM
Beside the measured number, compound 3's estimate is 1.8-fold (0.26 log units) above it; the measured number falls inside the stated range.
By their numbers in this assay, from the lowest: compound 2; then compound 3; then compound 1.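

In this assay the group on the amide-type nitrogen in the ring proves to have a strong hold on the number: with the rest of compound 1 left as it is, putting 4-fluoropyridin-2-yl in place of 5-(ethoxycarbonyl)-4-methyl-1,3-thiazol-2-yl gives a 13-fold lower number from compound 1 to compound 3 (1.11 log units; beyond the scatter) and counts as a large step. The first two compounds differ in more than one place, so their gap could not be tied to any single part, whereas this step ties a change to this position alone. It also shows that the ester-bearing thiazole is not required here, since a ring with fewer heavy atoms gives the stronger inhibitor of this pair, though nothing in the data gives a reason for the size of the step.

The swap changes the ring size, the ring atoms and the substituents all at once, so the step cannot be divided among the ester, the methyl group, the fluorine and the pyridine nitrogen. On these data alone, how a plain phenyl ring, or a thiazole carrying a carboxylic acid in place of the ethyl ester, would behave at this position remains open.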